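A few compounds are considered here, and "the series" means these few. Any claim that something is new, unique, unknown or untested is made for them only; others in the source may bear on it.

Three compounds of the series have been run in a functional assay on MRC5 cells (Homo sapiens); a lower number here means that less compound is tolerated, a higher number that more compound is tolerated. Compound 1 `Cc1ccc(CN2c3ccccc3C(=O)N(Cc3ccccc3)S2(=O)=O)cc1` gives 63000 nM in this assay. Compound 2 `COc1ccc(CN2c3ccccc3C(OCc3ccccc3)=NS2(=O)=O)cc1` gives 61000 nM in this assay, and compound 3 `O=C1c2ccccc2N(Cc2ccccc2)S(=O)(=O)N1Cc1ccccc1Cl` gives 60000 nM in this assay. Compound 1 carries the highest of the three numbers, but its gap to compound 2 and its gap to compound 3 both lie within the scatter, so this assay does not separate the three compounds.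

Compound 4 `O=C1c2ccccc2N(Cc2cccc(Cl)c2)S(=O)(=O)N1Cc1ccccc1` has not been measured. Relative to compound 1 the change is 3-chlorophenyl in place of 4-methylphenyl on a saturated chain carbon bound to a sulfonamide nitrogen in a ring. Among the compounds with values here, no pair of measured compounds differs in only one place, so no directly comparable step is available. The three measured numbers sit together, and compound 3, which also carries a chlorine on a benzyl group of the shared core, gives 60000 nM in this assay. For compound 4 the expectation is therefore a step no larger than the scatter, a 1.1-fold lower number from compound 1 to compound 4 (0.04 log units; within the scatter), in this assay. Compound 4 is estimated at 58000 nM, with a range from 30000 nM to 110000 nM.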

Compound 4, half-maximal cytotoxic concentration: 60000 nM
The estimate for compound 4 lay 1.0-fold (0.01 log units) below the measured number, and the stated range covers the measured number.
By their numbers in this assay, from the lowest: compounds 3, 4, 2 and 1 (each within the scatter of the next).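

The exchange of 4-methylphenyl for 3-chlorophenyl, on a saturated chain carbon bound to a sulfonamide nitrogen in a ring, gives the series its first step that can be read directly: in this assay it is a 1.1-fold lower number from compound 1 to compound 4 (0.02 log units; within the scatter) and so does not separate the two compounds. Within the data shown here, at this place, then, this one change of both the substituent and where it sits on the phenyl ring leaves the read-out within the scatter, which the earlier compounds, with no single-place pair among them, could only suggest. No measured evidence available here accounts for this result.

Still open, from the compounds shown here alone, is whether this place stays as flat with a group of another kind, such as a carboxylic acid, a primary amine or a longer chain in place of the benzyl group. Also open, going by these compounds, is whether the other benzyl group on the shared core responds any differently to a single change of this sort.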